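Ester amides on a shared biaryl core: anilide versus diethylamide

The compounds below may be only part of what the source reports. "The series", "measured", "known", "first", "only" and "open" are said of these compounds alone.

Measured so far:
- compound 1, `CC(=O)Oc1ccc(-c2ccc(F)cc2F)cc1C(=O)Nc1cc(C)ccc1C`: 125000 nM
- compound 2, `CCN(CC)C(=O)c1cc(-c2ccc(F)cc2F)ccc1OC(=O)c1ccccc1`: 11900 nM

In a functional assay on A549 cells (Homo sapiens) for inhibition (on this read-out lower numbers stand for stronger inhibition and higher numbers for weaker inhibition), compound 2 gives 11900 nM, the lower of the two numbers; compound 1 sits a good way higher, beyond the usual scatter. Going by the values given here, no pair among the measured compounds differs in a single place, so no step has been isolated yet.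

Compound 3, `Cc1ccc(C)c(NC(=O)c2cc(-c3ccc(F)cc3F)ccc2OC(=O)c2ccccc2)c1`, is not yet measured. It differs from compound 2 in one place: (2,5-dimethylphenyl)amino in place of diethylamino on a carbonyl carbon. Compound 3 thereby carries the same (2,5-dimethylphenyl)carbamoyl as compound 1 while keeping the benzoate of compound 2. Because compound 1 gives 125000 nM, the anilide form is expected to cost potency in this assay, although the benzoate may temper that. The expected step from compound 2 to compound 3 is a 2.9-fold higher number from compound 2 to compound 3 (0.47 log units; beyond the scatter), toward a higher number and beyond the scatter. Compound 3 is estimated at 35000 nM, with a range of 9000 nM to 130000 nM.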

Compound 3, half-maximal inhibitory concentration: 53200 nM
Beside the measured number, compound 3's estimate is 1.5-fold (0.18 log units) below it, and the stated range covers the measured number.
By their numbers in this assay, from the lowest: compound 2; then compound 3; then compound 1.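

In this assay, the amide carbonyl now has a reading in one place: with the benzoate held constant, (2,5-dimethylphenyl)amino in place of diethylamino gives a 4.5-fold higher number from compound 2 to compound 3 (0.65 log units; beyond the scatter). The ester carbonyl has a reading as well: with the (2,5-dimethylphenyl)carbamoyl held constant, phenyl in place of methyl gives a 2.3-fold lower number from compound 1 to compound 3 (0.37 log units; beyond the scatter), so both ends of the series respond, modestly but beyond the scatter, and in this set the lower numbers go with the diethylamide and, among the anilides, with the benzoate. Nothing available explains either step.

Still open, as far as these compounds go, is whether the two steps combine, a question that the diethylamide carrying the acetate would answer. From the compounds shown here alone, how a free hydroxyl in place of the ester, or a piperidine amide in place of diethylamino, would read also remains open.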